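A few compounds are considered here, and "the series" means these few. Any claim that something is new, unique, unknown or untested is made for them only; others in the source may bear on it.

Measured so far:
Compound 1, `Fc1ccccc1/C=C/c1nnc(-c2ccc3c(c2)OCCO3)o1`: 402000 nM
Compound 2, `C(=C/c1nnc(-c2ccc3c(c2)OCCO3)o1)\c1ccccc1`: 209000 nM

In an ADME assay on HUVEC cells (Homo sapiens) for cytotoxicity, read by MTT assay, with a stated time of 24 h (on this read-out higher numbers stand for lower toxicity in this test and lower numbers for higher toxicity in this test), compound 1 gives 402000 nM, and compound 2 gives 209000 nM. These two numbers sit within the scatter of each other, so on the evidence so far compound 2 cannot be told apart from compound 1. Going by the values given here, the only step yet measured, a 1.9-fold lower number from compound 1 to compound 2 (0.28 log units; within the scatter), came from swapping hydrogen for fluoro on an aromatic carbon.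

Compound 3, `COc1cccc(/C=C/c2nnc(-c3ccc4c(c3)OCCO4)o2)c1`, differs from compound 2 in one place: methoxy in place of hydrogen on an aromatic carbon. Among the compounds with values here, no measured step involves a methoxy group, so the fluoro step is the only guide, and it showed nothing beyond the scatter. A step of similar size, and so no clear change, is therefore expected in this assay, namely a 1.2-fold higher number from compound 2 to compound 3 (0.08 log units; within the scatter). Compound 3 is estimated at 250000 nM, with a likely range from 100000 nM to 600000 nM.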

Compound 3, half-maximal cytotoxic concentration: 332000 nM
Estimate against measurement, compound 3: 1.3-fold (0.12 log units) below; low and high end bracket the measured number.
By their numbers in this assay, from the lowest: compounds 2, 3 and 1 (each within the scatter of the next).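

In this assay, putting methoxy on the aromatic ring, meta to a large group, gives a 1.6-fold higher number from compound 2 to compound 3 (0.20 log units; within the scatter), so at this position a group with an oxygen atom cannot yet be told apart from plain hydrogen. Replacing 2-fluorophenyl with 3-methoxyphenyl gives a 1.2-fold lower number from compound 1 to compound 3 (0.08 log units; within the scatter), also within the scatter, so a change of both the group and its place on the ring produces no clear difference in this test. No measurement shown here explains these numbers.

As far as these compounds go, it remains open whether an amine, a carboxylic acid or a longer chain such as butoxy on this ring would shift the number beyond the scatter. From the compounds shown here alone, it is equally open whether a change to the shared core would do so.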